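The compounds below may be only part of what the source reports. "The series", "measured", "known", "first", "only" and "open" are said of these compounds alone.

The three measured compounds share one amide chain and differ only in the aromatic group attached to the carbonyl. Compound 1 `O=C(NCCCn1ccnc1)c1cc2ccccc2s1`, carrying a fused bicyclic aromatic group, gives 1100 nM in an assay on isolated protein for inhibition of Nicotinamide phosphoribosyltransferase (Homo sapiens), read by fluorescence, with a stated time of 15 min; on this read-out higher numbers stand for weaker inhibition and lower numbers for stronger inhibition. Compound 2 `Cc1ccsc1C(=O)NCCCn1ccnc1` reaches only the limit of this assay, > 10000 nM, which is not a number; this is the limit of > 10000 nM in this assay, at which 1 of the 3 values shown sits. Compound 3 `Cc1ccc(C(=O)NCCCn2ccnc2)s1` gives 170 nM in this assay, the lowest of the two numbers available, with compound 1 the nearest and its number higher by a margin beyond the usual scatter.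

The unmeasured compound 4 `O=C(NCCCn1ccnc1)c1ccc([N+](=O)[O-])s1` differs from compound 3 by nitro in place of methyl on an aromatic carbon. For the measured compounds named here, no measured pair shows an exchange of this kind, so the direction is not anchored by the compounds at hand. A step of modest size toward a higher number is expected, one that may still fall within the scatter. Compound 4 is therefore expected to give about 400 nM in this assay, in a range from 80 nM to 3000 nM. The expected step is a 2.4-fold higher number from compound 3 to compound 4 (0.37 log units; beyond the scatter).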

Compound 4, half-maximal inhibitory concentration: > 10000 nM
Compound 4 gave a limit, no number (the forecaster's own chance of this, stated with the estimate: 10%); middle value at least 25-fold (1.39 log units) away from the limit.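

For the compounds shown here, the exchange of methyl for nitro on the aromatic carbon next to the ring sulfur gives an at least 58-fold higher number from compound 3 to compound 4 (1.76 log units; beyond the scatter), the first sign that this position does not accept every group: the earlier compounds held no exchange at this place. In this assay compound 4 gives > 10000 nM, which is a limit and not a number. Compound 4 thus joins compound 2 at that limit, so the step from the methyl compound marks a lower bound on the change and not its full size: the limit of > 10000 nM in this assay, at which 2 of the 4 values shown sit.

The compounds shown leave open whether the change follows from nitro itself or from any group other than methyl at this position. A hydrogen, a chlorine, an ethyl or an amine on the same carbon would separate these two readings.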